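The source may report more compounds than this note shows. Statements on the series, on what has been measured and on what is new or still open speak of the compounds shown alone.

Measured in a functional assay on C6 cells (Rattus norvegicus) for cytotoxicity, read by MTT assay, with a stated time of 24 h, tested at 6 ug/mL; on this read-out lower numbers stand for a stronger effect and higher numbers for a weaker effect at the one concentration tested:
compound 1 `Cc1nnc(SCC(=O)N/N=c2/scc(-c3ccc(Cl)cc3)n2-c2ccccc2)s1` — 82.8%
compound 2 `O=C(CSc1ncccn1)N/N=c1/scc(-c2ccc(Cl)cc2)n1-c1ccccc1` — 95.9%
compound 3 `Cc1ccc(-c2cs/c(=N/NC(=O)CSc3ncccn3)n2-c2ccccc2)cc1` — 93.2%

Two single changes connect these. Compound 3 differs from compound 2 by methyl in place of chloro on an aromatic carbon, and in this assay that gives a number 2.7 percentage points lower from compound 2 to compound 3 (within the scatter). Going by the values given here, compound 1 differs from compound 2 by 5-methyl-1,3,4-thiadiazol-2-yl in place of pyrimidin-2-yl on a sulfur, and in this assay that gives a number 13.1 percentage points lower from compound 2 to compound 1 (beyond the scatter), the only step here beyond the scatter.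

Compound 4 `Cc1ccc(-c2cs/c(=N/NC(=O)CSc3nnc(C)s3)n2-c2ccccc2)cc1` is not yet measured. It differs from compound 3 by 5-methyl-1,3,4-thiadiazol-2-yl in place of pyrimidin-2-yl on a sulfur. The place of this change reads the same word for word as in the pair of compound 2 and compound 1, so it is the same change made on the other core.

In this assay compound 4 is expected to give about 80%, between 68% and 92%, because a number 13.1 percentage points lower from compound 2 to compound 1 (beyond the scatter). The expected step is a number 13.2 percentage points lower from compound 3 to compound 4 (beyond the scatter), resting on a single prior example of the change.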

Compound 4, a percentage reported as activity, at one concentration (the size of the read-out at that concentration, not a potency): 65.9%
Estimate against measurement, compound 4: 14.1 percentage points above; the whole stated range lies above it.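

In this assay, 5-methyl-1,3,4-thiadiazol-2-yl in place of pyrimidin-2-yl on a sulfur lowers the number on both cores, here with a number 27.3 percentage points lower from compound 3 to compound 4 (beyond the scatter), but the size does not carry over: the same change on two cores in this assay, a number 13.1 percentage points lower (beyond the scatter) from compound 2 to compound 1 and a number 27.3 percentage points lower (beyond the scatter) from compound 3 to compound 4, 14.2 percentage points apart, beyond the scatter of two such steps

Methyl in place of chloro on an aromatic carbon, with a number 16.9 percentage points lower from compound 1 to compound 4 (beyond the scatter), depends on its partner in the same way: the same change on two cores in this assay, a number 2.7 percentage points lower (within the scatter) from compound 2 to compound 3 and a number 16.9 percentage points lower (beyond the scatter) from compound 1 to compound 4, 14.2 percentage points apart, beyond the scatter of two such steps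

The direction of the sulfur change therefore held in both available pairs, while its size depended on the core, and these four compounds do not show why or whether this would hold on any further core.

Still open, on these data alone, is whether a methoxy group on the aromatic carbon, or an amine or a carboxylic acid in place of the ring on the sulfur, would follow the same course.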